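A few compounds are considered here, and "the series" means these few. Any claim that something is new, unique, unknown or untested is made for them only; others in the source may bear on it.

In a functional assay on SNB-19 cells (Homo sapiens) for inhibition, read by sulforhodamine B assay, with a stated time of 48 h (on this read-out lower numbers stand for stronger inhibition of growth and higher numbers for weaker inhibition of growth), compound 1 `Cc1ccc(C2=NN(c3ccc(S(C)(=O)=O)cc3)C(=O)CC2)cc1` gives 1250 nM, while compound 2 `Cc1cc(O)ccc1C1=NN(c2ccc(S(C)(=O)=O)cc2)C(=O)CC1` gives 50400 nM, the higher of the two numbers and so the weaker inhibition of growth. For the measured compounds named here, the one measured step, a 40-fold higher number from compound 1 to compound 2 (1.61 log units; beyond the scatter), is large and came with 4-hydroxy-2-methylphenyl in place of 4-methylphenyl on a carbon with a double bond to nitrogen. Compound 3 `CCc1ccc(C2=NN(c3ccc(S(C)(=O)=O)cc3)C(=O)CC2)cc1` has not yet been measured. It carries 4-ethylphenyl in place of 4-hydroxy-2-methylphenyl at that same carbon: 4-ethylphenyl in place of 4-hydroxy-2-methylphenyl on a carbon with a double bond to nitrogen. Going by the values given here, the group that leaves is the one that separates compound 2 from compound 1, and the group that enters looks more like the 4-methylphenyl of compound 1. A large step towards a lower number is therefore expected in this assay, undoing most of the rise seen in a 40-fold higher number from compound 1 to compound 2 (1.61 log units; beyond the scatter). The expected change is a 34-fold lower number from compound 2 to compound 3 (1.53 log units; beyond the scatter). Among the compounds with values here, no measured compound shows how 4-ethylphenyl behaves, so the range stays wide. For compound 3 the estimated value is 1500 nM, with an expected range from 500 nM to 5000 nM.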

Compound 3, concentration for 50% growth inhibition: 130 nM
Compound 3: the middle estimate sits 12-fold (1.06 log units) above what was measured; measured number outside the range, below it.
By their numbers in this assay, from the lowest: compound 3; then compound 1; then compound 2.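

The step of a 9.6-fold lower number from compound 1 to compound 3 (0.98 log units; beyond the scatter) in this assay shows that this position can also move towards stronger inhibition of growth, whereas the earlier compounds had shown only a loss, and that the addition of a single methyl to the chain of the 4-methylphenyl group is enough for a modest change beyond the scatter. The step of a 390-fold lower number from compound 2 to compound 3 (2.59 log units; beyond the scatter) is large, although 4-hydroxy-2-methylphenyl and 4-ethylphenyl both have 8 heavy atoms and one six-membered aromatic ring of carbon only, so the heavy-atom count and the ring do not account for the difference, while the counts of donors and acceptors do differ, 1 of each leaving and 0 of each entering. No measurement offered here explains why either change alters growth inhibition.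

The compounds shown leave open whether a longer chain such as propyl, or a branched one such as isopropyl, would continue the trend from methyl to ethyl or reverse it. They also leave open how much of the weak result for compound 2 belongs to its hydroxyl and how much to its additional methyl, since the two groups appear only together.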